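A few compounds are considered here, and "the series" means these few. Any claim that something is new, unique, unknown or untested is made for them only; others in the source may bear on it.

Measured so far in a functional assay on HeLa cells (Homo sapiens) for antiproliferative activity, read by sulforhodamine B assay, with a stated time of 72 h; on this read-out higher numbers stand for weaker inhibition and lower numbers for stronger inhibition:
- compound 1 `S=C(NCc1ccccc1)N/N=C/c1ccc2ccccc2n1`: 62800 nM
- compound 2 `CN(C)C(=S)N/N=C/c1nc2ccccc2s1`: 2100 nM

Compound 1, at 62800 nM, has the higher of the two numbers and so the weaker inhibition. Compound 2 lies below it, beyond the scatter, but differs from it in more than one place. Compound 3 `S=C(N/N=C/c1ccc2ccccc2n1)Nc1ccc(Br)cc1` keeps the core of compound 1 and carries 4-bromophenyl in place of benzyl on an amide-type nitrogen. For the measured compounds named here, no measured pair shows this change alone, so the expectation is loose: a moderate move towards stronger inhibition in this assay. The expected size is a 5.2-fold lower number from compound 1 to compound 3 (0.72 log units; beyond the scatter). Compound 3 is estimated at 12000 nM, with an expected range of 2500 nM to 55000 nM.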

Compound 3, half-maximal inhibitory concentration: 56800 nM
Beside the measured number, compound 3's estimate is 4.7-fold (0.68 log units) below it; measured number outside the range, above it.
By their numbers in this assay, from the lowest: compound 2; then compounds 3 and 1 (each within the scatter of the next).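

Putting 4-bromophenyl in place of benzyl on the amide-type nitrogen gives, in this assay, a 1.1-fold lower number from compound 1 to compound 3 (0.04 log units; within the scatter) and so the two compounds cannot be told apart. For the compounds shown here, this is the first pair that differs in one place, and it shows that these two groups are interchangeable at this position in this assay. No further measurement offers an explanation for this.

As far as these compounds go, whether a morpholine ring or a longer alkyl chain on this nitrogen would shift the number remains open. Also open, from the compounds shown here alone, is which of the several differences between compound 2 and compound 1 goes with the lower number of compound 2.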